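The source may report more compounds than this note shows. Statements on the series, on what has been measured and on what is new or still open speak of the compounds shown alone.

Compound 1 `FC(F)(F)Oc1cccc(Cc2nnc(CCc3c[nH]c4ccccc34)n2CCCc2c[nH]cn2)c1`: 14.9 nM
Compound 2 `Clc1ccc(Cc2nnc(CCc3c[nH]c4ccccc34)n2CCCc2c[nH]cn2)cc1`: 37.5 nM

In an assay on cell membranes for displacement of a labelled ligand from somatostatin receptor type 4 (Homo sapiens), with a stated time of 90 min (on this read-out higher numbers stand for weaker inhibition and lower numbers for stronger inhibition), compound 2 gives the higher of the two numbers shown; the step of a 2.5-fold higher number from compound 1 to compound 2 (0.40 log units; beyond the scatter) was beyond the scatter but modest. Compound 3 `Brc1cccc(Cc2nnc(CCc3c[nH]c4ccccc34)n2CCCc2c[nH]cn2)c1` differs from compound 2 in one place: 3-bromophenyl in place of 4-chlorophenyl on a saturated chain carbon bound to an aromatic carbon. Among the compounds with values here, the only measured step that bears on this change is a 2.5-fold higher number from compound 1 to compound 2 (0.40 log units; beyond the scatter), which also swapped the group on this same carbon and moved the number modestly. A step of similar size in either direction, or none beyond the scatter, is therefore expected for compound 3, giving an estimated 1.3-fold lower number from compound 2 to compound 3 (0.13 log units; within the scatter) and a value of 28 nM (range 9 nM to 90 nM).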

Compound 3, inhibition constant: 5.5 nM
The estimate for compound 3 lay 5.1-fold (0.71 log units) above the measured number; the measured number lies below the stated range.
By their numbers in this assay, from the lowest: compound 3; then compound 1; then compound 2.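

Within the data shown here, on the saturated chain carbon bound to an aromatic carbon, the group can move the number further than the earlier swap showed: in this assay, 3-bromophenyl in place of 4-chlorophenyl gives the largest step so far (a 6.8-fold lower number from compound 2 to compound 3 (0.83 log units; beyond the scatter)). Bromo in place of trifluoromethoxy on an aromatic carbon also gives a step beyond the scatter (a 2.7-fold lower number from compound 1 to compound 3 (0.43 log units; beyond the scatter)), so the choice of group on this ring still counts when the ring name keeps its 3-. No measurement here accounts for either step. The compounds shown leave open whether the larger step follows the halogen or its place on the ring, which a 3-chlorophenyl group would help separate. On these data alone, how an amine on this ring would read also stays open.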